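Aniline ring swap on the shared core

The source may report more compounds than this note shows. Statements on the series, on what has been measured and on what is new or still open speak of the compounds shown alone.

Compound 2 `COc1ccc(NC2=CC(=O)c3c(nc4n3[C@H]3OC[C@@H](O)[C@H]3OC4)C2=O)cc1` carries a 4-methoxyphenyl on the amine nitrogen of the shared core. Going by the values given here, in a functional assay on MCF7 cells (Homo sapiens) for inhibition, read by sulforhodamine B assay (a lower number here means a stronger inhibitor, a higher number a weaker inhibitor), compound 2 gives 4470 nM, the lowest of the two numbers in hand, with compound 1 `CCc1ccc(NC2=CC(=O)c3c(nc4n3[C@H]3OC[C@@H](O)[C@H]3OC4)C2=O)cc1` as its only neighbour; in this assay compound 1 gives 8990 nM. Among the compounds with values here, the single measured step, a 2.0-fold lower number from compound 1 to compound 2 (0.30 log units; within the scatter), is the only comparison available and stays within the scatter.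

Compound 3 `O=C1C(Nc2cccc(F)c2)=CC(=O)c2c1nc1n2[C@H]2OC[C@@H](O)[C@H]2OC1` differs from compound 2 by 3-fluorophenyl in place of 4-methoxyphenyl on an amine nitrogen. Within the data shown here, no measured step bears on this change: the step from compound 1 to compound 2 puts methoxy in place of ethyl on an aromatic carbon and leaves the aromatic ring itself in place, whereas here the whole aromatic substituent on the amine nitrogen is exchanged. Among the measured compounds shown here, with no relevant step, and the one step seen lying within the scatter, no movement beyond the scatter is expected in this assay; the expected step is a 1.4-fold higher number from compound 2 to compound 3 (0.15 log units; within the scatter), set near no change with a wide range. Compound 3 is estimated at 6300 nM in this assay, expected to fall between 2200 nM and 18000 nM.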

Compound 3, half-maximal inhibitory concentration: > 4000 nM
Compound 3 gave a limit, no number; the forecaster's own chance of this, stated with the estimate: 5%; the middle value lies beyond the limit too.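

In this assay compound 3 gives > 4000 nM, which is a limit and not a number. The steps to compound 3 from compound 1 and from compound 2 cannot be read. The compounds shown leave open whether 3-fluorophenyl on the amine nitrogen of the shared core moves the number in this assay relative to 4-methoxyphenyl or 4-ethylphenyl.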